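A few compounds are considered here, and "the series" means these few. Any claim that something is new, unique, unknown or untested is made for them only; others in the source may bear on it.

In a functional assay on cells for agonist activity at D(4) dopamine receptor (Homo sapiens), read by TR-FRET and cAMP accumulation, with a stated time of 30 min (a lower number here means a smaller maximal response, a higher number a larger maximal response), three compounds have been measured. Compound 1 `Cc1cccc(NC(=O)CN2CCN(c3cccc4ccccc34)CC2)c1` reaches 27.8%, only part of the reference response. Compound 2 `Cc1cccc(NC(=O)CN2CCN(c3ccc(Cl)cn3)CC2)c1` is reported as "not active" (no number reported), with no number given. Compound 3 `Cc1ccc(C2CCN(CC(=O)Nc3cccc(C)c3)CC2)nc1` is likewise reported as "not active" (no number reported) in this assay, so no figure stands for it, and one further compound shares that status. Compound 4 `Cc1cccc(NC(=O)CN2CCC(c3ccccc3)CC2)c1` differs from compound 3 in one place: phenyl in place of 5-methylpyridin-2-yl on a saturated ring carbon. Going by the values given here, no step between two measured compounds matches this change, so its size can only be guessed. Since compound 3 gave "not active" (no number reported), the expectation is that compound 4 stays weak, with any rise likely small. Compound 4 is expected to give 18% in this assay, in a range from 0% to 45%.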

Compound 4, largest response reached (Emax), in percent of the reference or control that the assay uses: 32.9%
Compound 4: the middle estimate sits 14.9 percentage points below what was measured; low and high end bracket the measured number.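

Going by these compounds alone, compound 3 has no number, so no step from it to compound 4 can be read. The compounds shown leave open how much phenyl in place of 5-methylpyridin-2-yl changes the response. No measurement shown offers an explanation for this result.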